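The compounds below may be only part of what the source reports. "The series", "measured", "known", "first", "only" and "open" are said of these compounds alone.

Compound 1 `COc1cc(O)c(C(=O)/C=C/c2ccc(O)cc2)c(OC)c1` — 6900 nM in a functional assay on B16-F10 cells (Mus musculus) for inhibition, with a stated time of 4 days; a lower number here means a stronger inhibitor, a higher number a weaker inhibitor
Compound 2 `CCc1ccccc1/C=C/C(=O)c1c(O)cc(OC)cc1OC` — 2500 nM

Of the two measured compounds, compound 2 stands with the lowest number in this assay; compound 1 gives a higher number, and that gap lies beyond the usual scatter of the measurement. Within the data shown here, no single-change step between measured compounds is available here.

Compound 3 `COc1cc(O)c(C(=O)/C=C/c2ccccc2O)c(OC)c1` differs from compound 2 in one place: hydroxy in place of ethyl on an aromatic carbon. Among the measured compounds shown here, the only measured compound that carries a hydroxy on the ring in question is compound 1, which in this assay gives 6900 nM, a weaker result than compound 2. On that basis compound 3 is expected to move back toward the weaker side, an upward step in number, probably beyond the scatter but not large. Compound 3 is estimated at 5000 nM, with a range from 2000 nM to 14000 nM. That estimate means an expected step of a 2.0-fold higher number from compound 2 to compound 3 (0.30 log units; within the scatter).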

Compound 3, half-maximal inhibitory concentration: 2300 nM
Compound 3: the middle estimate sits 2.2-fold (0.34 log units) above what was measured; low and high end bracket the measured number.
By their numbers in this assay, from the lowest: compounds 3 and 2 (each within the scatter of the next); then compound 1.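

In this assay, hydroxy in place of ethyl on an aromatic carbon ortho to a large group gives a 1.1-fold lower number from compound 2 to compound 3 (0.04 log units; within the scatter) and so leaves the read-out unchanged within the scatter, showing that this position accepts either group in this assay. The placement of the hydroxy does count: 2-hydroxyphenyl in place of 4-hydroxyphenyl gives a 3.0-fold lower number from compound 1 to compound 3 (0.48 log units; beyond the scatter) in a modest step, something the first two compounds could not show. Nothing measured here explains either step.

The compounds shown leave open whether an amine, a carboxylic acid or a longer chain at this position would also stay level with ethyl and hydroxy or would shift the number. They also leave open whether the result holds outside these three compounds on the shared core.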